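This account rests on a few compounds, and the source may have more. Where it says the series, first, only, none or still open, it means among the compounds named here.

Working notes on the series. Compound 1 `CC(/C=N/Nc1ccc([N+](=O)[O-])cc1)=N\NC(=O)c1ccccc1Cl` and compound 2 `CC(/C=N/Nc1ccc([N+](=O)[O-])cc1)=N\NC(=O)c1ccccc1F` carry a halogenated phenyl group on the carbonyl carbon, while compound 3 `COc1cc(C(=O)N/N=C(C)/C=N/Nc2ccc([N+](=O)[O-])cc2)ccc1O` carries a 4-hydroxy-3-methoxyphenyl group there. In a functional assay on cells (Splenocyte, Mus musculus, strain BALB/c) for inhibition, read by scintillation counting and thymidine incorporation, with a stated time of 72 h (on this read-out lower numbers stand for stronger inhibition and higher numbers for weaker inhibition), compound 1 gives > 12000 nM, which is a limit of the assay and not a number. Compound 2 gives > 12000 nM in this assay, again a limit. Within the data shown here, compound 3 gives 5100 nM in this assay, the only real number in the set; the two other values sit at the limit of > 12000 nM in this assay, at which 2 of the 3 values shown sit. The step that the two limits leave unreadable from compound 1 to compound 2 is unreadable, whereas an at least 2.3-fold lower number from compound 1 to compound 3 (0.37 log units; beyond the scatter) and an at least 2.3-fold lower number from compound 2 to compound 3 (0.37 log units; beyond the scatter) are both beyond the scatter, though only bounded from one side.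

Compound 4 `CC(/C=N/Nc1ccc([N+](=O)[O-])cc1)=N\NC(=O)c1ccc(N(C)C)cc1` differs from compound 3 by 4-(dimethylamino)phenyl in place of 4-hydroxy-3-methoxyphenyl on a carbonyl carbon. Among the measured compounds shown here, no measured step exchanges one group for another in that place without also involving the halogenated phenyl groups of compound 1 and compound 2, so the measured steps give only weak guidance; they show that the group on the carbonyl carbon can move a value from a limit into the readable range, and a move back is possible. The expected step of a 1.2-fold higher number from compound 3 to compound 4 (0.07 log units; within the scatter) in this assay is estimated as small, likely within the scatter. Compound 4 is expected to give about 6000 nM in this assay, within 2000 nM to 15000 nM.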

Compound 4, half-maximal inhibitory concentration: > 12000 nM
Compound 4 gave a limit, no number; the forecaster's own chance of this, stated with the estimate: 35%; at least 2.0-fold (0.30 log units) between middle value and limit.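

In this assay, the exchange of 4-hydroxy-3-methoxyphenyl for 4-(dimethylamino)phenyl on a carbonyl carbon gives an at least 2.3-fold higher number from compound 3 to compound 4 (0.37 log units; beyond the scatter). The earlier steps set the 4-hydroxy-3-methoxyphenyl group only against halogenated phenyl groups, whereas this one shows that a phenyl group without halogen can also leave the readable range, so the absence of halogen alone does not give a readable value among these compounds. The steps from compound 1 and from compound 2 to compound 4 cannot be read, and compound 3 remains the only compound with a number: the limit of > 12000 nM in this assay, at which 3 of the 4 values shown sit.

The compounds shown leave open whether a phenyl group carrying only the hydroxy group or only the methoxy group would keep a readable value. They also leave open how a carboxylic acid or a primary amine on that phenyl group would read.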